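Inversion of one ring stereocentre in a lipid phosphoserine analogue

A few compounds are considered here, and "the series" means these few. Any claim that something is new, unique, unknown or untested is made for them only; others in the source may bear on it.

Measured compounds:
- compound 1, `CCCCCCCC/C=C\CCCCCCCC(=O)O[C@H]1C=CCO[C@@H]1COP(=O)(O)OC[C@H](N)C(=O)O`: "not active" (no number reported)
- compound 2, `CCCCCCCCCCCOc1ccccc1CCC(=O)OCc1cccc(OP(=O)(O)OC[C@H](N)C(=O)O)c1`: 0.23
- compound 3, `CCCCCCCCCCCOc1ccccc1CCC(=O)OC[C@H]1OCC=C[C@@H]1OP(=O)(O)OC[C@H](N)C(=O)O`: 0.071

In an assay on HEK293-A cells with putative P2Y purinoceptor 10 (Mus musculus) as the target, with a stated time of 1.5 h (on this read-out higher numbers stand for larger maximal responses and lower numbers for smaller maximal responses), compound 1 is reported as "not active" (no number reported), so no single number stands for it. Compound 2 gives 0.23 in this assay. Compound 3 shares the ring core of compound 1, and in this assay compound 3 gives 0.071. Compound 4, `CCCCCCCC/C=C\CCCCCCCC(=O)O[C@@H]1C=CCO[C@@H]1COP(=O)(O)OC[C@H](N)C(=O)O`, has not yet been measured. Compared with compound 1 it shows (the two compounds have the same atoms and bonds; at least one stereo element is drawn with a configuration in one of them and without one in the other: 1 of 5 stereo elements differ; a stereocentre at a saturated ring carbon is drawn S in compound 1 and R in compound 4). Going by the values given here, no measured pair shows what such a change does in this assay, so the expected step is uncertain; a small response of the size seen for compound 3 is expected. Compound 4 is estimated at 0.08 in this assay, with a range from 0 to 0.3.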

Compound 4, intrinsic activity: the largest response reached, as a fraction of the reference agonist's: "not active" (no number reported)
Compound 4 has no reported number here, and the estimate cannot be compared.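

In this assay compound 1 gives "not active" (no number reported) and compound 4 gives "not active" (no number reported), so no step can be read between them. The compounds shown leave open whether inverting this ring stereocentre changes the response at all.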